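The source may hold more compounds than are shown below. What is called first, only, known or untested is meant among the compounds shown, and "the series" means these compounds.

Compound 1 `O=C(CCCCC1CCSS1)Nc1ccc(Br)cn1` ends its chain in a small sulfur-containing ring. In a functional assay on Bel-7402 cells (Homo sapiens) for inhibition, read by MTT assay, with a stated time of 24 h, tested at 10 ug/mL (a higher number here means more inhibition of growth at the concentration tested, a lower number less inhibition of growth), compound 1 gives 24.5%. Compound 3 `O=C(CCCCC(S)CCS)Nc1ccc(Br)cn1` keeps the same core and opens that ring: a group of 5 heavy atoms (3 carbon, 2 sulfur; no ring) in place of a group of 5 heavy atoms (3 carbon, 2 sulfur; one five-membered non-aromatic ring with 2 hetero atoms), on a saturated chain carbon, four bonds along the chain from a carbonyl carbon. In this assay compound 3 gives 23.2%, so that the step of a number 1.3 percentage points lower from compound 1 to compound 3 (within the scatter). Compound 2 `O=C(CCCCC1CCSS1)Nc1cccc2ccccc12` carries the ring-closed chain on a different core; the difference between the two cores is not broken down here. In this assay compound 2 gives 6.27%, the lowest of the three numbers, with its gaps to compound 1 and to compound 3 both lying beyond the scatter. Compound 4 `O=C(CCCCC(S)CCS)Nc1cccc2ccccc12` has not yet been measured. It stands to compound 2 as compound 3 stands to compound 1: a group of 5 heavy atoms (3 carbon, 2 sulfur; no ring) in place of a group of 5 heavy atoms (3 carbon, 2 sulfur; one five-membered non-aromatic ring with 2 hetero atoms), on a saturated chain carbon, four bonds along the chain from a carbonyl carbon, the same change at the same place. The step from compound 2 to compound 4 is expected to be a number 0.3 percentage points lower from compound 2 to compound 4 (within the scatter), because a number 1.3 percentage points lower from compound 1 to compound 3 (within the scatter) stayed within the scatter and the change is the same. Compound 4 is therefore estimated at 6%, expected to fall between -4% and 16%.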

Compound 4, percent growth inhibition at one concentration: "not active" (no number reported)
The entry for compound 4 holds no number; there is nothing to compare the estimate with.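

In this assay, for the compounds shown here, compound 4 is recorded only as "not active", without a number, so no step from compound 2 to compound 4 can be read. Nothing shown here accounts for that entry. As far as these compounds go, whether opening the ring changes growth inhibition on the core of compound 2 remains open.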